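Carbonyl aryl exchange in the ketone series: compound 3 to 4

The compounds below may be only part of what the source reports. "The series", "measured", "known", "first", "only" and "open" are said of these compounds alone.

Measured so far in a functional assay on CHO-K1 cells for antagonist activity at adenosine receptor A2b (Homo sapiens), read by FLIPR and calcium flux; a lower number here means a stronger inhibitor, a higher number a weaker inhibitor:
- compound 1 `CCc1nc(C(=O)c2ccc(C)s2)c2sccc2n1` gives 3670 nM
- compound 2 `CCNc1nc(C(=O)c2ccc(C)s2)c2sccc2n1` gives 1260 nM
- compound 3 `O=C(c1ccc(Cl)s1)c1nc(NCc2cccnc2)nc2ccsc12` gives 487 nM

Compound 3 holds the lowest number of the three in this assay; compound 2 is nearest and compound 1 furthest, both gaps beyond the scatter. Among the compounds with values here, the only single-point step measured so far, a 2.9-fold lower number from compound 1 to compound 2 (0.46 log units; beyond the scatter), concerns the aromatic carbon of the shared core and not the ketone side.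

Compound 4 `O=C(c1ccncc1)c1nc(NCc2cccnc2)nc2ccsc12` differs from compound 3 at the carbonyl: pyridin-4-yl in place of 5-chlorothiophen-2-yl on a carbonyl carbon. Within the data shown here, no measured pair in this set varies the group on the carbonyl carbon, so no step here bears on the change directly; the only reference is compound 3 itself, together with the spread of the three values. With nothing to anchor the direction, the expectation for compound 4 is a step of a 1.3-fold higher number from compound 3 to compound 4 (0.13 log units; within the scatter), that is, no change beyond the scatter is assumed, but with a wide range. The estimate for compound 4 in this assay is 650 nM, expected to fall between 150 nM and 3000 nM.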

Compound 4, half-maximal inhibitory concentration: 869 nM
Estimate against measurement, compound 4: 1.3-fold (0.13 log units) below; the measured number falls inside the stated range.
By their numbers in this assay, from the lowest: compounds 3, 4 and 2 (each within the scatter of the next, the first and the last beyond it); then compound 1.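

In this assay, within the data shown here, pyridin-4-yl in place of 5-chlorothiophen-2-yl on a carbonyl carbon gives a 1.8-fold higher number from compound 3 to compound 4 (0.25 log units; within the scatter), the first single-point reading on the ketone side of the series. This assay therefore does not separate the five-membered sulfur- and chlorine-bearing aromatic ring from the six-membered aromatic ring with one nitrogen at this position, so neither the sulfur nor the chlorine is needed for a value of this order. No supporting data offer an explanation for this outcome.

Open, from the compounds shown here alone, is whether an unsubstituted phenyl or a saturated ring such as cyclohexyl on the carbonyl carbon stays in this range. Also open, going by these compounds, is whether the same exchange reads alike when the ethylamino group of compound 2 stands on the shared core.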